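The source may report more compounds than this note shows. Statements on the series, on what has been measured and on what is new or still open speak of the compounds shown alone.

Measured so far in a functional assay on DLD-1 cells (Homo sapiens) for cytotoxicity, read by MTT assay, with a stated time of 72 h; a lower number here means a stronger inhibitor, a higher number a weaker inhibitor:
- compound 1 `COc1cc(/C=N/c2c(C)n(C)n(-c3ccccc3)c2=O)ccc1O`: 759000000 nM
- compound 2 `Cc1c(/N=C/c2ccc(Cl)cc2)c(=O)n(-c2ccccc2)n1C`: 631000000 nM

Two compounds share the core and differ in the group carried by the imine-linked aromatic ring. In this assay compound 2 gives 631000000 nM, the lower of the two numbers on record; the nearest neighbour is compound 1, whose number lies within the scatter of that of compound 2, so the two cannot be placed in an order. Both values sit far up the scale, in the region where the read-out reports only very weak cytotoxicity.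

Compound 3 `Cc1c(/N=C/c2ccc(O)cc2)c(=O)n(-c2ccccc2)n1C` has not been measured. Relative to compound 2 the change is hydroxy in place of chloro on an aromatic carbon. Among the measured compounds shown here, no step between measured compounds covers this exchange, and the two numbers in hand give no direction to extrapolate from. The working expectation is that the step from compound 2 to compound 3 in this assay is a 1.1-fold higher number from compound 2 to compound 3 (0.05 log units; within the scatter), that is, nothing beyond the scatter. Compound 3 is therefore estimated at 700000000 nM, with a range from 250000000 nM to 2000000000 nM.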

Compound 3, half-maximal inhibitory concentration: 646000000 nM
Compound 3: the middle estimate sits 1.1-fold (0.03 log units) above what was measured, within the range that was stated.
By their numbers in this assay, from the lowest: compounds 2, 3 and 1 (each within the scatter of the next).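

In this assay, chloro and hydroxy at this position, on an aromatic carbon para to a large group, cannot be told apart: the exchange gives a 1.0-fold higher number from compound 2 to compound 3 (0.01 log units; within the scatter), even though a hydrogen-bond donor and a hydrogen-bond acceptor enter with the hydroxy. The series also gains its first readable single-place change on the same ring, hydrogen in place of methoxy on an aromatic carbon, which gives a 1.2-fold lower number from compound 1 to compound 3 (0.07 log units; within the scatter), so this change also stays inside the scatter and the 4-hydroxyphenyl compound offers no handle on the read-out. No supporting data bear on why these numbers stay so close.

On these data alone, all three compounds remain in the same very weak region of the scale, so it stays open whether any group at this position can move the number beyond the scatter, for example an amine, a carboxylic acid or a longer alkoxy chain in place of the hydroxy. Also open, as far as these compounds go, is whether replacing the phenyl or the methyl groups on the shared core with other groups would shift the number in a way that changes on the imine-linked ring have not.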